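The compounds below may be only part of what the source reports. "The series", "measured", "known", "first", "only" and "open" are said of these compounds alone.

The measured compounds:
compound 1, `Cc1ccc(S(=O)(=O)N2C=CNC(=O)[C@H]2CC(=O)N[C@@H]2CCCc3cc(CN4CCCC4)ccc32)cc1`, gives 0.084 nM in an in vitro functional assay on cells for antagonist activity at B1 bradykinin receptor (Homo sapiens), read by luminescence and calcium flux, with a stated time of 2 h; on this read-out lower numbers stand for stronger inhibition and higher numbers for weaker inhibition;
compound 2, `Cc1ccc(S(=O)(=O)N2C=CNC(=O)[C@H]2CC(=O)N[C@@H]2CCc3ccccc32)cc1`, gives 94.7 nM in this assay;
compound 3, `Cc1ccc(S(=O)(=O)N2C=CNC(=O)[C@H]2CC(=O)N[C@@H]2CCC(O)c3ccccc32)cc1`, gives 1.47 nM in this assay.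

All three share the same core and differ only in the ring-bearing group attached to the amide nitrogen. On the numbers shown, compound 2 stands at the highest value, meaning the weakest inhibition of the three. Compound 3 lies nearer to it and compound 1 lies furthest from it, and both gaps are well beyond the scatter of repeated measurements, so the group on that nitrogen clearly matters a great deal.

Compound 4, `Cc1ccc(S(=O)(=O)N2C=CNC(=O)[C@H]2CC(=O)NC2CCC(C)CC2)cc1`, has not yet been measured. Compared with compound 2 the change is 4-methylcyclohexyl in place of 2,3-dihydro-1H-inden-1-yl on an amide-type nitrogen. This removes the aromatic ring altogether and leaves a simple saturated ring with a methyl group; it also removes the one defined stereocentre in that part of the molecule. Among the measured compounds shown here, no measured pair shows this kind of change, so the direction has to be guessed. Since compound 2 already gives 94.7 nM and the two stronger compounds both keep an aromatic ring in this position, the expectation is a further step toward weaker inhibition, of modest to large size: the expected step is a 4.2-fold higher number from compound 2 to compound 4 (0.63 log units; beyond the scatter). The estimate for compound 4 in this assay is 400 nM, with a plausible range from 60 nM to 4000 nM.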

Compound 4, half-maximal inhibitory concentration: 314 nM
Estimate against measurement, compound 4: 1.3-fold (0.11 log units) above, within the range that was stated.
By their numbers in this assay, from the lowest: compound 1; then compound 3; then compound 2; then compound 4.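

In this assay, replacing the 2,3-dihydro-1H-inden-1-yl group with 4-methylcyclohexyl gives a 3.3-fold higher number from compound 2 to compound 4 (0.52 log units; beyond the scatter), a real but modest loss. An aromatic ring on this amide nitrogen is therefore not essential for inhibition, since compound 4, which has only a saturated ring there, still gives a measurable value of 314 nM. This single swap changes several things at once: it removes the aromatic ring and the defined stereocentre and also changes the ring size and the number of carbons, so the step cannot be assigned to any one of them, and nothing here offers an explanation for it.

The compounds shown leave open whether a plain cyclohexyl group, without the methyl, or a simple benzyl group would sit closer to compound 4 or to compound 2, which would help separate the effect of the aromatic ring from that of the fused ring system. They also leave open whether a saturated ring can benefit from added groups as the fused rings seem to, for example a hydroxyl group or a pyrrolidin-1-ylmethyl group on the cyclohexyl ring.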